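The source may report more compounds than this note shows. Statements on the series, on what has been measured and on what is new or still open speak of the compounds shown alone.

Measured so far:
compound 1, `COc1ccc(N(C(=O)CN2C=CN(c3cccnc3)C(=O)C(Cc3n[nH]c4cc(F)ccc34)C2=O)C(C)C)cc1`, 661 nM
compound 2, `O=C1C(Cc2n[nH]c3cc(F)ccc23)C(=O)N(c2ccccc2)C=CN1CC(=O)N1CCCCc2ccccc21`, 437 nM

Both compounds were run in a functional assay on CHO cells for agonist activity at Melanocortin receptor 4 (Homo sapiens), read by a luciferase reporter, with a stated time of 4 h; a lower number here means that less compound is needed, a higher number that more compound is needed for the effect. Compound 1 gives 661 nM and compound 2 gives 437 nM. On these two numbers compound 2 sits at the smaller one, yet the gap to compound 1 lies within the scatter of the method, so the two cannot be told apart.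

Compound 3, `COc1ccc(N(C(=O)CN2C=CN(c3ccccc3)C(=O)C(Cc3n[nH]c4cc(F)ccc34)C2=O)C(C)C)cc1`, is not yet measured. Relative to compound 2 the change is a group of 12 heavy atoms (10 carbon, 1 nitrogen, 1 oxygen; one six-membered aromatic ring of carbon only) in place of a group of 11 heavy atoms (10 carbon, 1 nitrogen; one six-membered aromatic ring of carbon only, one seven-membered non-aromatic ring with 1 hetero atom), on a carbonyl carbon. The entering isopropyl(4-methoxyphenyl)amino group is the same one found on the carbonyl carbon of compound 1, which gives 661 nM in this assay; the rest of compound 3 matches compound 2. For the measured compounds named here, no measured pair here isolates this single change, so no step size can be read off. Given that compound 1 and compound 2 lie within the scatter of each other, compound 3 is expected to land near both, with a step of a 1.3-fold higher number from compound 2 to compound 3 (0.10 log units; within the scatter) that is not expected to exceed the scatter. The estimate for compound 3 in this assay is 550 nM, with a range from 200 nM to 1500 nM.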

Compound 3, half-maximal effective concentration: 355 nM
Beside the measured number, compound 3's estimate is 1.5-fold (0.19 log units) above it; measured number inside the range.
By their numbers in this assay, from the lowest: compounds 3, 2 and 1 (each within the scatter of the next).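

In this assay, for the compounds shown here, the first single-place comparison on the carbonyl carbon gives a 1.2-fold lower number from compound 2 to compound 3 (0.09 log units; within the scatter), so isopropyl(4-methoxyphenyl)amino and the group with the seven-membered non-aromatic ring cannot be told apart at this place. Going by these compounds alone, the series also gains a first reading on the amide-type nitrogen in a ring, where phenyl in place of pyridin-3-yl gives a 1.9-fold lower number from compound 1 to compound 3 (0.27 log units; within the scatter), so these two groups cannot be told apart there either. No measurement on hand bears on these results, and the size of either step receives no explanation from the data.

Going by these compounds, each of the groups compared at these two places contains a six-membered aromatic ring, so it remains open whether a smaller group or one without such a ring, such as dimethylamino on the carbonyl carbon or methyl or cyclohexyl on the amide-type nitrogen in a ring, would give a step beyond the scatter. The rest of the shared core, including its fluorine, is the same in all three compounds, so these numbers say nothing about replacing that fluorine with hydrogen or chlorine.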